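Aryl exchange on the shared core: cytotoxicity notes

The source may hold more compounds than are shown below. What is called first, only, known or untested is meant among the compounds shown, and "the series" means these compounds.

Compound 1 `COc1nc(-c2cccc(Cl)c2)ccc1[C@@H](c1ccccc1)[C@@](O)(CCN(C)C)c1cccc2ccccc12` gives in a toxicity assay on Vero cells (Chlorocebus sabaeus) for cytotoxicity (a lower number here means that less compound is tolerated, a higher number that more compound is tolerated), only a limit, > 50 ug/mL, and so stands at the limit of > 50 ug/mL in this assay, at which 1 of the 2 values shown sits, rather than at a number. Compound 2 `COc1nc(-c2ccsc2)ccc1[C@@H](c1ccccc1)[C@@](O)(CCN(C)C)c1cccc2ccccc12` gives 24.4 ug/mL in this assay. Within the data shown here, the only measured step, an at least 2.0-fold lower number from compound 1 to compound 2 (0.31 log units; beyond the scatter), runs downward from that limit. Compound 3 `COc1nc(-c2ccc(C#N)cc2)ccc1[C@@H](c1ccccc1)[C@@](O)(CCN(C)C)c1cccc2ccccc12` carries 4-cyanophenyl in place of 3-chlorophenyl on an aromatic carbon. Among the measured compounds shown here, no measured step includes this 4-cyanophenyl, and the step to compound 2 swaps the same 3-chlorophenyl for a different group, so it bears only loosely on this change. Compound 3 is therefore expected near the limit, allowing a modest drop, an at least 1.2-fold lower number from compound 1 to compound 3 (0.09 log units; that floor lies within the scatter). The estimate for compound 3 is 40 ug/mL, expected within 15 ug/mL to 80 ug/mL.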

Compound 3, half-maximal cytotoxic concentration: > 50 ug/mL
Compound 3: no number, only a limit; the forecaster's own chance of this, stated with the estimate: 40%; at least 1.2-fold (0.09 log units) between middle value and limit.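

In this assay compound 3 gives > 50 ug/mL, a limit and not a number. Placing 4-cyanophenyl where thiophen-3-yl stood gives an at least 2.0-fold higher number from compound 2 to compound 3 (0.31 log units; beyond the scatter), so the thiophen-3-yl group is the only one of the three aryl groups with a readable number. The two substituted phenyl groups both end at the same limit: the limit of > 50 ug/mL in this assay, at which 2 of the 3 values shown sit.

The step between 3-chlorophenyl and 4-cyanophenyl cannot be read, since both values are limits. From the compounds shown here alone, how a furan-3-yl or an aminophenyl group at this position would behave in this assay remains open.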